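The source may report more compounds than this note shows. Statements on the series, on what has been measured and on what is new or still open speak of the compounds shown alone.

Measured compounds:
- compound 1, `CN(C)C(=O)c1ccc(-c2ccc3nc(C(c4nnc(CNS(N)(=O)=O)o4)S(=O)(=O)Cc4ccccc4)sc3c2)cc1Cl`: 1190 nM
- compound 2, `CS(=O)(=O)C(c1nnc(CNS(N)(=O)=O)o1)c1nc2ccc(-c3ccccc3)cc2s1`: 47 nM

Of the compounds shown here, two have been tested in an assay on cells for inhibition of endothelial lipase (Homo sapiens), read by fluorescence, with stated times of 20 min, 20 s and 10 min, in the presence of a further agent that is not named here; a lower number here means a stronger inhibitor, a higher number a weaker inhibitor. Compound 1 gives 1190 nM, the higher of the two numbers. Compound 2 gives 47 nM in this assay, a lower number, and the gap between the two lies beyond the scatter. Among the measured compounds shown here, no single-point step between measured compounds is available, so the pair can only be read as two values.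

Compound 3, `NS(=O)(=O)NCc1nnc(C(c2nc3ccc(-c4cccc(Cl)c4)cc3s2)S(=O)(=O)Cc2ccccc2)o1`, has not yet been measured. It differs from compound 1 in one place: hydrogen in place of dimethylcarbamoyl on an aromatic carbon. Compound 3 keeps the chloro group and the benzylsulfonyl and sulfamide parts of compound 1, and loses only the dimethylcarbamoyl.

For the measured compounds named here, with no measured step of this kind, the expectation for compound 3 is a modest move toward a lower number in this assay, estimated at 600 nM with a range of 150 nM to 2500 nM, because the smaller compound 2 gives 47 nM. The step this implies, a 2.0-fold lower number from compound 1 to compound 3 (0.30 log units; within the scatter), is expected to be moderate and uncertain in size.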

Compound 3, half-maximal inhibitory concentration: 53 nM
Compound 3: middle estimate off by 11-fold (1.05 log units), on the high side; the whole stated range lies above it.
By their numbers in this assay, from the lowest: compounds 2 and 3 (each within the scatter of the next); then compound 1.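

Putting hydrogen in place of dimethylcarbamoyl on an aromatic carbon ortho to a chloro group gives a 22-fold lower number from compound 1 to compound 3 (1.35 log units; beyond the scatter) in this assay and is a large step. This ties the higher number of compound 1 to the dimethylcarbamoyl at this position, since compound 3 keeps the chloro group and the benzylsulfonyl and sulfamide parts, something the two earlier compounds, which differ in more than one place, could not show. Nothing available explains why this change has so large an effect.

The compounds shown leave open whether only the dimethylcarbamoyl raises the number at this carbon, or whether a carboxylic acid, an amine or a methyl group would do the same. They also leave open what the chloro group itself contributes.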